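The compounds below may be only part of what the source reports. "The series", "measured", "known", "first", "only" and "open" are said of these compounds alone.

Compound 3, whose structure is `CC1CCN(c2c(S(=O)(=O)c3cc(F)cc(F)c3)cnc3c(F)cccc23)CC1`, sits at the bottom of the three numbers. In an assay on isolated protein for displacement of a labelled ligand from metabotropic glutamate receptor 5 (Homo sapiens), with a stated time of 60 min, tested at 1 uM (a higher number here means more inhibition at the concentration tested (going by the name of the read-out), a lower number less inhibition), compound 3 gives 9%, while compound 1 `Cc1ccc(S(=O)(=O)c2cnc3c(F)cccc3c2N2CCC(C)CC2)cc1` gives 93% and compound 2 `CC1CCN(c2c(S(=O)(=O)c3cccc(F)c3)cnc3c(F)cccc23)CC1` gives 62%. The drops a number 84 percentage points lower from compound 1 to compound 3 (beyond the scatter) and a number 53 percentage points lower from compound 2 to compound 3 (beyond the scatter) are both beyond the scatter, as is the intermediate drop a number 31 percentage points lower from compound 1 to compound 2 (beyond the scatter).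

Compound 4 `CC1CCN(c2c(S(=O)(=O)c3ccc(Cl)cc3)cnc3c(F)cccc23)CC1` differs from compound 3 in one place: 4-chlorophenyl in place of 3,5-difluorophenyl on a sulfonyl sulfur. For the measured compounds named here, three measured steps bear on this change. The two fluorine-bearing rings on the sulfonyl sulfur, in compounds 2 and 3, fall well short of the 4-methylphenyl of compound 1, and the second fluorine in compound 3 lowers the number further by a number 53 percentage points lower from compound 2 to compound 3 (beyond the scatter). The 4-chlorophenyl entering in compound 4 carries no fluorine and, like the 4-methylphenyl of compound 1, a single substituent named at position 4, so the account expects the read-out to move back up, though a chlorine is not a methyl and the exact size is uncertain.

Compound 4 is therefore expected to rise by a number 66 percentage points higher from compound 3 to compound 4 (beyond the scatter) in this assay. The estimate for compound 4 is 75%, with a range from 45% to 95%.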

Compound 4, a percentage reported as inhibition, at one concentration (the size of the read-out at that concentration, not a potency): 85%
The estimate for compound 4 lay 10 percentage points below the measured number; measured number inside the range.
By their numbers in this assay, from the lowest: compound 3; then compound 2; then compounds 4 and 1 (each within the scatter of the next).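

In this assay the 4-chlorophenyl on the sulfonyl sulfur gives a number 76 percentage points higher from compound 3 to compound 4 (beyond the scatter) and also a number 23 percentage points higher from compound 2 to compound 4 (beyond the scatter), which shows that the low numbers of the two fluorine-bearing rings do not extend to every substituted phenyl at this place. Chloro in place of methyl on the aromatic carbon gives a number 8 percentage points lower from compound 1 to compound 4 (within the scatter), so the 4-chlorophenyl and the 4-methylphenyl cannot be told apart in this assay, and among these four compounds, with none going against it, the two rings with a single group at position 4 give higher numbers than the two carrying fluorine. Nothing given here explains these differences.

The compounds shown leave open whether the fluorine itself or its place on the ring accounts for the lower numbers, a question on which a 4-fluorophenyl or an unsubstituted phenyl would bear. They also leave open how compound 1 and compound 4 compare in potency, since a read-out at one concentration does not give a potency.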